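Trading an Amine Side Chain for a Diol

A few compounds are considered here, and "the series" means these few. Any claim that something is new, unique, unknown or untested is made for them only; others in the source may bear on it.

Compound 1 `CCn1c(C(=O)NCCN(C)C)ccc1C(CC)(CC)c1ccc(OCCC(O)(CC)CC)c(C)c1` is an amide whose side chain ends in a dimethylamino group. In an ADME assay on L02 cells (Homo sapiens) for antiproliferative activity, read by MTT assay, with a stated time of 48 h (a lower number here means a stronger inhibitor, a higher number a weaker inhibitor), compound 1 gives 990 nM, the lowest of the two numbers measured here. Compound 2 `CCN(CC)CCNC(=O)c1ccc(C(CC)(CC)c2ccc(OCCC(O)(CC)CC)c(C)c2)n1CC` carries a diethylamino group instead; in this assay compound 2 gives 2290 nM, and there is a 2.3-fold higher number from compound 1 to compound 2 (0.36 log units; beyond the scatter). Compound 3 `CCn1c(C(=O)Nc2cccc(C(F)(F)F)c2)ccc1C(CC)(CC)c1ccc(OCCC(O)(CC)CC)c(C)c1` puts an aromatic ring on the amide nitrogen; in this assay compound 3 reaches only a limit, > 50000 nM. The step of an at least 50-fold higher number from compound 1 to compound 3 (1.70 log units; beyond the scatter) rests on that limit (the limit of > 50000 nM in this assay, at which 1 of the 3 values shown sits). Compound 4 `CCn1c(C(=O)NC(CO)CCO)ccc1C(CC)(CC)c1ccc(OCCC(O)(CC)CC)c(C)c1` alters the same side chain: 3-hydroxy-1-(hydroxymethyl)propyl in place of 2-(dimethylamino)ethyl on an amide-type nitrogen. The small change to compound 2 was modest, the large change to compound 3 removed nearly all activity; this swap is expected to land between them, as a clear rise in the number. Compound 4 is estimated at 8000 nM, between 2500 nM and 30000 nM, which is expected to mean an 8.1-fold higher number from compound 1 to compound 4 (0.91 log units; beyond the scatter).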

Compound 4, half-maximal inhibitory concentration: 3040 nM
For compound 4 the middle estimate is 2.6-fold (0.42 log units) above the measured one; the range from low to high includes it.
By their numbers in this assay, from the lowest: compound 1; then compounds 2 and 4 (each within the scatter of the next). At a limit, above all of these: compound 3.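

In this assay, the side chain on the amide-type nitrogen need not carry an amine to keep a number near those of the amine compounds: there is a 3.1-fold higher number from compound 1 to compound 4 (0.49 log units; beyond the scatter), and a 1.3-fold higher number from compound 2 to compound 4 (0.12 log units; within the scatter). Compound 4 thus shows that the large loss seen with 3-(trifluoromethyl)phenyl does not follow from removing the amine alone. Compound 3 has a limit, not a number, so there is an at least 16-fold lower number from compound 3 to compound 4 (1.21 log units; beyond the scatter), a step that rests on this: the limit of > 50000 nM in this assay, at which 1 of the 4 values shown sits.

On these data alone, whether a carboxylic acid, a 2-hydroxyethyl group or a longer chain at this position would behave like compound 4 remains open.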